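A Methyl Replaces a Phenyl on a Shared Core

A few compounds are considered here, and "the series" means these few. Any claim that something is new, unique, unknown or untested is made for them only; others in the source may bear on it.

Compound 2 `Cc1cc2nc(-c3ccccc3)nc(N)c2c(=O)[nH]1` was tested in an assay on isolated protein for inhibition of RAC-beta serine/threonine-protein kinase (Homo sapiens), read by mobility shift assay, tested at 30 uM (on this read-out lower numbers stand for less inhibition and higher numbers for more inhibition at the one concentration tested (going by the name of the read-out)), where compound 2 gives 2%. Going by the values given here, the only other measured compound, compound 1 `Cc1cc2nc(N)nc(N)c2c(=O)[nH]1`, gives 0%, and the two numbers lie within the scatter of each other, so neither number can be called higher or lower than the other. Among the compounds with values here, the one measured step, a number 2 percentage points higher from compound 1 to compound 2 (within the scatter), therefore shows no effect beyond the scatter.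

Compound 3 `Cc1nc(N)c2c(=O)[nH]c(C)cc2n1` has not yet been measured. It differs from compound 2 in one place: methyl in place of phenyl on an aromatic carbon. Within the data shown here, no measured step exchanges phenyl for methyl, so the only guide is that the single change at this position, a number 2 percentage points higher from compound 1 to compound 2 (within the scatter), stayed within the scatter. Compound 3 is accordingly expected to remain where both measured compounds sit, with the step of a number 1 percentage points lower from compound 2 to compound 3 (within the scatter) estimated to fall within the scatter. The estimate for compound 3 is 1%, within a range from -8% to 10%.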

Compound 3, a percentage reported as inhibition, at one concentration (the size of the read-out at that concentration, not a potency): 2%
For compound 3 the middle estimate is 1 percentage points below the measured one, and the stated range covers the measured number.
By their numbers in this assay, from the lowest: compounds 1, 2 and 3 (each within the scatter of the next).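

Three groups at this position, on an aromatic carbon between two ring nitrogen atoms, can now be compared in this assay. Replacing phenyl with methyl gives no change at the digits printed from compound 2 to compound 3 (within the scatter), and replacing amino with methyl gives a number 2 percentage points higher from compound 1 to compound 3 (within the scatter), so neither step moves the number beyond the scatter, even though the group shrinks from a six-carbon aromatic ring to a single carbon in the first step. Nothing measured here offers an explanation for this flat result.

Still open, on these data alone, is whether a carboxylic acid or a longer chain such as butyl at this position would give a number beyond the scatter of these three compounds. Also open, as far as these compounds go, is whether a change elsewhere on the shared core would move the number at all.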